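The compounds below may be only part of what the source reports. "The series", "measured", "known", "first", "only" and "open" are said of these compounds alone.

In a functional assay (Homo sapiens) for antiproliferative activity (a lower number here means a stronger inhibitor of growth, a higher number a weaker inhibitor of growth), three compounds have been measured:
compound 1 `Cc1sc2nc(-c3ccncc3)c(/C=N/NC(=N)N)n2c1C` gives 43700 nM;
compound 2 `Cc1cn2c(/C=N/NC(=N)N)c(-c3cccnc3)nc2s1` gives 7080 nM;
compound 3 `Cc1sc2nc(-c3ccccn3)c(/C=N/NC(=N)N)n2c1C` gives 22900 nM.

Compound 3 stands second highest of the three, nearest compound 1 and furthest from compound 2, whose number is lower. Among the measured compounds shown here, the only single-place step known, a 1.9-fold lower number from compound 1 to compound 3 (0.28 log units; within the scatter), concerns the pyridyl group and does not touch the methyl. Compound 4 `Cc1cn2c(/C=N/NC(=N)N)c(-c3ccccn3)nc2s1` differs from compound 3 by hydrogen in place of methyl on an aromatic carbon. For the measured compounds named here, no measured step bears on this change; compound 2, which also lacks that methyl, differs from compound 3 in two places, so its lower value gives only a weak hint. Compound 4 is therefore expected to show a 1.5-fold lower number from compound 3 to compound 4 (0.18 log units; within the scatter) in this assay, with the change likely within the scatter. The estimate for compound 4 is 15000 nM, with a range from 5000 nM to 45000 nM.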

Compound 4, concentration for 50% growth inhibition: 8910 nM
Compound 4: middle estimate off by 1.7-fold (0.23 log units), on the high side; the measured number falls inside the stated range.
By their numbers in this assay, from the lowest: compounds 2 and 4 (each within the scatter of the next); then compounds 3 and 1 (each within the scatter of the next).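

In this assay, among the compounds shown here, hydrogen in place of methyl on the aromatic carbon next to the ring nitrogen gives a 2.6-fold lower number from compound 3 to compound 4 (0.41 log units; beyond the scatter), the only single-place step at this position, and it lies beyond the scatter. Without that methyl, the pyridyl change gives a 1.3-fold higher number from compound 2 to compound 4 (0.10 log units; within the scatter), so pyridin-2-yl and pyridin-3-yl cannot be told apart here. No measurement at hand accounts for either step. From the compounds shown here alone, it remains open how an ethyl chain, an amine or a carboxylic acid on this carbon would compare with methyl and hydrogen. Going by these compounds, it also remains open whether the methyl step holds with pyridin-4-yl.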